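This account rests on a few compounds, and the source may have more. Where it says the series, first, only, none or still open, it means among the compounds named here.

Three compounds sharing one core were measured in a functional assay on ACHN cells (Homo sapiens) for inhibition, read by sulforhodamine B assay, with a stated time of 48 h, tested at 10 uM; a higher number here means more inhibition at the concentration tested (going by the name of the read-out), a lower number less inhibition. Compound 1 `c1ccc(-c2cn3ccnc3c(-c3ccc4ncn(C5CCCCC5)c4c3)n2)cc1` gives 35.9% in this assay, compound 2 `O=Cc1ccc(-c2cn3ccnc3c(-c3ccc4ncn(C5CCCCC5)c4c3)n2)cc1` gives 11.6%, and compound 3 `COc1ccccc1-c1cn2ccnc2c(-c2ccc3ncn(C4CCCCC4)c3c2)n1` gives 4.48%. Compound 2 therefore sits beyond the scatter from the top: the change is a number 24.3 percentage points lower from compound 1 to compound 2 (beyond the scatter), whereas a number 7.1 percentage points lower from compound 2 to compound 3 (within the scatter) stays within the scatter. Compound 4 `O=Cc1ccc(-c2cn3ccnc3c(-c3ccc4ncn(Cc5ccccc5)c4c3)n2)cc1` differs from compound 2 by benzyl in place of cyclohexyl on an aromatic nitrogen. Among the compounds with values here, every measured step alters the substituent on the phenyl ring, the largest being a number 31.4 percentage points lower from compound 1 to compound 3 (beyond the scatter); none changes the group on the aromatic nitrogen, so no measured step bears on this change. With nothing pointing either way, the expected step is a number 0.4 percentage points higher from compound 2 to compound 4 (within the scatter), none beyond the scatter. Compound 4 is accordingly estimated at 12%, with a range from -5% to 35%.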

Compound 4, a percentage reported as inhibition, at one concentration (the size of the read-out at that concentration, not a potency): 11.6%
Beside the measured number, compound 4's estimate is 0.4 percentage points above it, within the range that was stated.
By their numbers in this assay, from the lowest: compounds 3, 2 and 4 (each within the scatter of the next); then compound 1.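

In this assay, benzyl in place of cyclohexyl on the aromatic nitrogen gives no change at the digits printed from compound 2 to compound 4 (within the scatter) and is the first step shown at this position. With 4-formylphenyl held constant, an aromatic six-membered ring of carbon and a non-aromatic one therefore cannot be told apart here, even though benzyl brings one more heavy atom. Nothing available explains this result. From the compounds shown here alone, whether the same holds with the unsubstituted phenyl of compound 1 remains open. So does the effect of a longer alkyl chain or a chain ending in an amine on that nitrogen.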